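Compound 4: Fluoro in Place of Iodo

A few compounds are considered here, and "the series" means these few. Any claim that something is new, unique, unknown or untested is made for them only; others in the source may bear on it.

Three compounds with a shared core were read in an ADME assay on cells (Erythrocyte, Homo sapiens), read by hemolysis, with a stated time of 1 h (on this read-out lower numbers stand for stronger inhibition and higher numbers for weaker inhibition), and give no exact figure. Compound 1 (`CC(=NNC(=S)Nc1cccc([N+](=O)[O-])c1)c1ccccn1`) reads > 10000 nM as a limit of the assay. Compound 2 (`CC(=NNC(=S)Nc1ccccc1[N+](=O)[O-])c1ccccn1`) reads > 10000 nM as a limit as well. Compound 3 (`CC(=NNC(=S)Nc1ccc(I)cc1)c1ccccn1`) also stands at > 10000 nM as a limit, so it has only a bound and no number.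

Compound 4 (`CC(=NNC(=S)Nc1ccc(F)cc1)c1ccccn1`) carries fluoro in place of iodo on an aromatic carbon. The step expected in this assay is none beyond the scatter, estimated as a number no higher from compound 3 to compound 4 (the limit leaves the size open) in either direction. That expectation rests on the limit of > 10000 nM in this assay, at which 3 of the 3 values shown sit, across the series. The expected value for compound 4 is 10000 nM (estimated range 5000 nM to 30000 nM).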

Compound 4, half-maximal inhibitory concentration: > 10000 nM
Compound 4 gave a limit, no number (the forecaster's own chance of this, stated with the estimate: 85%); the middle value sits exactly at the limit.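

No new step can be read between compound 3 and compound 4: each gives only a limit in this assay. The compounds shown leave open what exact value any of them would give on this read-out.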